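Swapping Fluoro for Methyl on the Pendant Phenyl

This account rests on a few compounds, and the source may have more. Where it says the series, first, only, none or still open, it means among the compounds named here.

Measured compounds:
Compound 1, `CC(c1ccc(-c2ccccc2)c(F)c1)c1nnc2n1N=C(c1ccc(OC(F)(F)F)cc1)CS2`: 8400 nM
Compound 2, `CC(c1ccc(-c2ccccc2)c(F)c1)c1nnc2n1N=C(c1ccc(F)cc1)CS2`: 4900 nM

In a functional assay on Huh-7 cells (Homo sapiens) for inhibition, read by sulforhodamine B assay, with a stated time of 72 h (a lower number here means a stronger inhibitor, a higher number a weaker inhibitor), compound 2 gives 4900 nM, the smaller of the two numbers, though the step of a 1.7-fold lower number from compound 1 to compound 2 (0.23 log units; within the scatter) is within the scatter, so the two compounds cannot be told apart on this evidence. Compound 1 gives 8400 nM in this assay.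

Compound 3, `Cc1ccc(C2=Nn3c(nnc3C(C)c3ccc(-c4ccccc4)c(F)c3)SC2)cc1`, has not yet been measured. It differs from compound 2 by methyl in place of fluoro on an aromatic carbon. Going by the values given here, the one measured step at this same aromatic carbon, a 1.7-fold lower number from compound 1 to compound 2 (0.23 log units; within the scatter), changed the number by less than the scatter, and it is the only step that bears on the new change. On this basis no shift beyond the scatter is expected in this assay in either direction.

Compound 3 is therefore estimated to give 4900 nM, with a range of 2000 nM to 12000 nM, which means an expected step of no change at the digits printed from compound 2 to compound 3 (within the scatter).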

Compound 3, half-maximal inhibitory concentration: 7200 nM
Compound 3: middle estimate off by 1.5-fold (0.17 log units), on the low side; low and high end bracket the measured number.
By their numbers in this assay, from the lowest: compounds 2, 3 and 1 (each within the scatter of the next).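

In this assay the change from 4-fluorophenyl to 4-methylphenyl gives a 1.5-fold higher number from compound 2 to compound 3 (0.17 log units; within the scatter) and so does not separate the two compounds. With a 1.2-fold lower number from compound 1 to compound 3 (0.07 log units; within the scatter) as well, methyl, fluoro and trifluoromethoxy on this aromatic carbon cannot be told apart on these numbers. Going by these compounds alone, the earlier pair showed this for only two groups, both joined to the ring through an atom other than carbon, whereas methyl is joined through carbon and still falls within the scatter of both.

On these data alone, whether an amine or a carboxylic acid on this carbon would move the number beyond the scatter remains open. Nothing available here explains why these numbers lie so close together.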